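The source may hold more compounds than are shown below. What is called first, only, known or untested is meant among the compounds shown, and "the series" means these compounds.

Of the compounds shown here, two of a shared core have been measured so far. Compound 1 `Oc1ccc(-c2nc3cc(F)ccc3[nH]2)c(O)c1` carries two hydroxyl groups on its pendant ring, whereas compound 2 `COc1ccc(-c2nc3cc(F)ccc3[nH]2)c(Cl)c1OC` carries two methoxy groups and a chloro there. In an assay for inhibition of Alpha amylase (Homo sapiens), with a stated time of 10 min (on this read-out higher numbers stand for weaker inhibition and lower numbers for stronger inhibition), compound 1 gives 2980 nM. In this assay compound 2 gives 2560 nM. The two numbers lie within the usual scatter of each other, so neither compound can be set apart from the other on this evidence.

Compound 3 `COc1ccc(-c2nc3cc(Cl)ccc3[nH]2)c(Cl)c1OC` is not yet measured. It differs from compound 2 in one place: chloro in place of fluoro on an aromatic carbon. The exchange sits on the fused ring part of the core, away from the pendant ring that distinguishes compound 1 from compound 2. Among the compounds with values here, no measured pair of compounds here shows what a swap of this kind does, so there is nothing to lean on but the size of the change, which is a single halogen for another.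

The step is expected to be small, with no direction beyond the scatter, and the estimated step from compound 2 to compound 3 is a 1.2-fold lower number from compound 2 to compound 3 (0.07 log units; within the scatter). Compound 3 is therefore expected to give about 2200 nM, within a range from 800 nM to 6000 nM.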

Compound 3, half-maximal inhibitory concentration: 1510 nM
Estimate against measurement, compound 3: 1.5-fold (0.16 log units) above; measured number inside the range.
By their numbers in this assay, from the lowest: compounds 3, 2 and 1 (each within the scatter of the next).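

Within the data shown here, measured in this assay, chloro in place of fluoro on an aromatic carbon of the fused system gives a 1.7-fold lower number from compound 2 to compound 3 (0.23 log units; within the scatter) and provides the first comparison of two compounds that differ in only one place. This position therefore accepts either halogen with no change that can be separated from ordinary variation between repeated measurements, so the two compounds cannot be ranked on this evidence, and one pair is too little to support a general rule about halogens here. Nothing available bears on the reason for the size of this step.

The compounds shown leave open whether a group other than a halogen at this position, such as an amine or a carboxylic acid, would move the number beyond the scatter, and a larger change would say more about how much this part of the molecule matters in this assay than a swap of one halogen for another can. They also leave open what each substituent on the pendant ring contributes, since compound 1 and compound 2 differ there in more than one place.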